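This account rests on a few compounds, and the source may have more. Where it says the series, first, only, none or still open, it means among the compounds named here.

Measured in an ADME assay (liver) for metabolic stability, with Liver microsome (Rattus norvegicus) as the target, using microsomes and NADPH, with a stated time of 30 min; a higher number here means faster removal of the compound, a lower number slower removal:
Compound 1 `CC#C[C@H]1CN(S(=O)(=O)c2ccc(N)nc2)CCN1c1ncc(C(C)(O)C(F)(F)F)s1`: 87 mL.min-1.g-1
Compound 2 `CC#C[C@H]1CN(S(=O)(=O)c2ccc(N)nc2)CCN1c1ccc(S(N)(=O)=O)cc1`: 30 mL.min-1.g-1
Compound 3 `CC#C[C@H]1CN(S(=O)(=O)c2ccc(N)nc2)CCN1c1ccc(S(=O)(=O)Nc2ccccc2)cc1`: > 399 mL.min-1.g-1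

For compound 3, > 399 mL.min-1.g-1 is a limit of the assay and not a number. Compound 4 `CC#C[C@H]1CN(S(=O)(=O)c2ccc(N)nc2)CCN1c1ccc(S(C)(=N)=O)cc1` differs from it as follows: a group of 4 heavy atoms (1 carbon, 1 nitrogen, 1 oxygen, 1 sulfur; no ring) in place of a group of 10 heavy atoms (6 carbon, 1 nitrogen, 2 oxygen, 1 sulfur; one six-membered aromatic ring of carbon only), on an aromatic carbon. Going by the values given here, one measured step bears on this change. Phenyl in place of hydrogen on a sulfonamide nitrogen gave an at least 13-fold higher number from compound 2 to compound 3 (1.12 log units; beyond the scatter), a large step beyond the scatter. Compound 4 carries no such aromatic ring, so a large step to a lower number is expected in this assay. The expected change is an at least 9.9-fold lower number from compound 3 to compound 4 (0.99 log units; beyond the scatter). For compound 4 the estimated value is 40 mL.min-1.g-1, with an expected range from 15 mL.min-1.g-1 to 110 mL.min-1.g-1.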

Compound 4, intrinsic clearance in microsomes: < 14 mL.min-1.g-1
Compound 4 was reported as a limit; the forecaster's own chance of this, stated with the estimate: 4%; at least 2.8-fold (0.45 log units) between middle value and limit.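

In this assay the result for compound 4 is a limit and not a number: the limit of < 14 mL.min-1.g-1 in this assay, at which 1 of the 4 values shown sits.

Replacing phenylsulfamoyl with the smaller group with no ring gives an at least 28-fold lower number from compound 3 to compound 4 (1.45 log units; beyond the scatter). The earlier compounds had shown only a rise at this position, on adding phenyl, whereas here a group of equal heavy-atom count to the plain sulfonamide also lowers the number, with an at least 2.1-fold lower number from compound 2 to compound 4 (0.33 log units; beyond the scatter).

The compounds shown leave open where an amine or a carboxylic acid at this position would fall, and whether a methyl on the sulfonamide nitrogen would behave like phenyl. As far as these compounds go, how far the true value of compound 4 lies past its limit also stays open.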